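Compound 1 to Compound 4: One Chlorine Enters the Phenyl

The compounds below may be only part of what the source reports. "The series", "measured", "known", "first", "only" and "open" are said of these compounds alone.

Measured so far:
- Compound 1 `CN(C)c1ccc(/C=C2/SC(=Nc3ccccc3)NC2=O)cc1`: 500 nM
- Compound 2 `O=C1N/C(=N\c2ccc(Cl)cc2)S/C1=C/c1ccccc1O`: 1850 nM
- Compound 3 `CC(=O)Nc1ccc(/C=C2/S/C(=N/c3cccc(Cl)c3)NC2=O)cc1`: 1190 nM

Of the compounds shown here, three share a core and have been tested in a functional assay on NCI-H460 cells (Homo sapiens) for antiproliferative activity; on this read-out higher numbers stand for weaker inhibition and lower numbers for stronger inhibition. Compound 1 gives 500 nM, the lowest of the three numbers. Compound 3 gives 1190 nM, a gap that lies beyond the scatter, and compound 2 gives 1850 nM, further still. Compounds 2 and 3 each carry a chlorine on the phenyl of the core, but they also differ from compound 1 elsewhere, so no single change between any two measured compounds can be read off.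

Going by the values given here, compound 4 `CN(C)c1ccc(/C=C2/SC(=Nc3ccccc3Cl)NC2=O)cc1` is the one unmeasured compound. It differs from compound 1 in one place: chloro in place of hydrogen on an aromatic carbon, on an aromatic carbon of a six-membered aromatic ring of carbon only, ortho to a large group; read one bond further out, phenyl becomes 2-chlorophenyl.

Among the compounds with values here, no measured pair isolates this change, so the expected step from compound 1 to compound 4 in this assay, a 1.2-fold higher number from compound 1 to compound 4 (0.08 log units; within the scatter), is taken to be small and not beyond the scatter. Compound 4 is therefore estimated at 600 nM, with a range from 250 nM to 1500 nM.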

Compound 4, half-maximal inhibitory concentration: 730 nM
Compound 4: the middle estimate sits 1.2-fold (0.09 log units) below what was measured, and the stated range covers the measured number.
By their numbers in this assay, from the lowest: compounds 1, 4, 3 and 2 (each within the scatter of the next, the first and the last beyond it).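

In this assay, going by these compounds alone, chloro in place of hydrogen on an aromatic carbon, ortho to a large group, gives a 1.5-fold higher number from compound 1 to compound 4 (0.16 log units; within the scatter), the first change that can be read on its own. With phenyl becoming 2-chlorophenyl on the core of compound 1, this place accepts a chlorine with no difference that can be told from the scatter, something compound 2 and compound 3 could not show, as each differs from compound 1 in more than one place. Nothing available here speaks to why the step has this size.

As far as these compounds go, what stays open is whether this place is as undemanding for other groups, such as a methoxy, an amine or a carboxylic acid in place of the chloro. From the compounds shown here alone, it is also open whether a chloro on the other carbons of this phenyl would give a similar reading on the core of compound 1, and whether this single step would hold with a group other than the dimethylamino on the opposite end of the molecule.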